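Chloro for methyl on the shared core, meta-sulfonamide series

A few compounds are considered here, and "the series" means these few. Any claim that something is new, unique, unknown or untested is made for them only; others in the source may bear on it.

Compound 1 `COC1Oc2ccc(C)cc2C(=O)/C1=C\Nc1cccc(S(N)(=O)=O)c1` gives 2770 nM in an assay on isolated protein for inhibition of Intestinal-type alkaline phosphatase (Bos taurus), read by luminescence, with stated times of 5 min and 15 min (on this read-out lower numbers stand for stronger inhibition and higher numbers for weaker inhibition), the lowest of the two numbers measured. Compound 2 `COC1Oc2ccc(F)cc2C(=O)/C1=C\Nc1ccc(S(N)(=O)=O)cc1` gives 29100 nM in this assay, a gap beyond the scatter, though compound 2 differs from compound 1 in more than one place, so only the two values themselves can be compared. Compound 3 `COC1Oc2ccc(Cl)cc2C(=O)/C1=C\Nc1cccc(S(N)(=O)=O)c1` differs from compound 1 by chloro in place of methyl on an aromatic carbon. No single-site comparison of this kind exists in the series, so a step within the scatter is expected, with no clear direction. The expected step of a 1.1-fold lower number from compound 1 to compound 3 (0.04 log units; within the scatter) is accordingly small. Compound 3 is estimated at 2500 nM, within a range from 900 nM to 7000 nM.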

Compound 3, inhibition constant: 13600 nM
The estimate for compound 3 lay 5.4-fold (0.74 log units) below the measured number, and the stated range ends below it.
By their numbers in this assay, from the lowest: compound 1; then compound 3; then compound 2.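

Chloro in place of methyl on this aromatic carbon is not a neutral exchange in this assay: the only single-site comparison in the series gives a 4.9-fold higher number from compound 1 to compound 3 (0.69 log units; beyond the scatter). The position therefore responds to a change of one heavy atom, with hydrogen-bond donor and acceptor counts the same on both groups. Nothing measured here accounts for this step.

Open, on these data alone, is how a hydrogen, an amine or a carboxylic acid on this aromatic carbon would read. Also open, as far as these compounds go, is whether the same step holds with the sulfonamide placed as in compound 2.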